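Pyridin-3-yl to 1H-1,2,4-triazol-1-yl: Compound 4 Expected

The source may hold more compounds than are shown below. What is called first, only, known or untested is meant among the compounds shown, and "the series" means these compounds.

Of the compounds shown here, three sharing one core have been tested in a functional assay on a cell-free system (plasma) with sterol O-acyltransferase, Soat (Rattus norvegicus) as the target; a higher number here means that more compound is needed for the effect, a lower number that less compound is needed. Compound 1 `CSc1cc(C)nc(SC)c1NC(=O)N(Cc1ccccc1)Cc1cccc(-c2ccnn2C)c1` returns only a limit of the assay, < 1 mg/kg. Compound 3 `Cc1cc(C)c(NC(=O)N(Cc2cccc(-c3cnn(C)c3)c2)C2CCCCCC2)c(C)c1` likewise returns only a limit, < 1 mg/kg. Compounds 1 and 3 thus sit at the limit of < 1 mg/kg in this assay, at which 2 of the 3 values shown sit. Among the measured compounds shown here, compound 2 `Cc1cc(C)c(NC(=O)N(Cc2ccc(-c3cccnc3)cc2)C2CCCCCC2)c(C)c1` is the single compound with a number, giving 0.58 mg/kg in this assay, and so stands as the only anchor among the values shown. Compound 4 `Cc1cc(C)c(NC(=O)N(Cc2ccc(-n3cncn3)cc2)C2CCCCCC2)c(C)c1` has not been measured. It differs from compound 2 by 1H-1,2,4-triazol-1-yl in place of pyridin-3-yl on an aromatic carbon. For the measured compounds named here, no measured pair shows a change of this kind, so the step expected in this assay is small, within the scatter or a slight weakening. For compound 4 the estimate is 0.8 mg/kg, with a range from 0.3 mg/kg to 2.5 mg/kg. The expected step is a 1.4-fold higher number from compound 2 to compound 4 (0.14 log units; within the scatter).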

Compound 4, dose for half-maximal effect: > 1 mg/kg
Compound 4: no number, only a limit; the forecaster's own chance of this, stated with the estimate: 40%; middle value at least 1.2-fold (0.09 log units) away from the limit.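

In this assay, among the compounds shown here, putting 1H-1,2,4-triazol-1-yl in place of pyridin-3-yl, para to a large group, gives the only step that can be read at this position: an at least 1.7-fold higher number from compound 2 to compound 4 (0.23 log units; that floor lies within the scatter). That floor lies within the scatter, so the change is not shown to go beyond it, and its true size cannot be read. Compound 4 returns no number, only a limit of the assay: the limit of > 1 mg/kg in this assay, at which 1 of the 4 values shown sits.

Ring size and the count of hetero atoms change together here and remain unseparated. On these data alone, how an imidazol-1-yl or a phenyl group would read at this position stays open.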